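Working notes: methylsulfanyl on the phenyl of compound 3

The compounds below may be only part of what the source reports. "The series", "measured", "known", "first", "only" and "open" are said of these compounds alone.

Compound 1 `COc1cccc(NC(=O)c2nnn(Cc3ccc(C#N)cc3)c2N)c1` gives 2.5 mL.min-1.g-1
Compound 2 `COc1cccc(NC(=O)c2nnn(CC3CCNCC3)c2N)c1` gives < 0.5 mL.min-1.g-1 as a limit of the assay
Compound 3 `COc1cccc(NC(=O)c2nnn(Cc3ccccc3)c2N)c1` gives 3.7 mL.min-1.g-1

In an ADME assay on microsomes from liver (Mus musculus, strain CD1) for metabolic stability, read by HPLC, using NADPH, with a stated time of 30 min (on this read-out lower numbers stand for slow clearance and higher numbers for fast clearance), compound 3 stands level with compound 1 within the scatter, and it lies clearly apart from the limit of compound 2 (an at least 7.4-fold higher number from compound 2 to compound 3 (0.86 log units; beyond the scatter)). Compound 4 `COc1cccc(NC(=O)c2nnn(Cc3ccc(SC)cc3)c2N)c1` differs from compound 3 by methylsulfanyl in place of hydrogen on an aromatic carbon with methylsulfanyl in place of hydrogen on an aromatic carbon, para to a large group. The nearest measured change, also on an aromatic carbon, stays within the scatter (a 1.5-fold higher number from compound 1 to compound 3 (0.17 log units; within the scatter)). The step with piperidin-4-yl in place of 4-cyanophenyl (an at least 5.0-fold lower number from compound 1 to compound 2 (0.69 log units; beyond the scatter)) is a different change and bears less on this one. No step beyond the scatter is therefore expected (a 1.2-fold higher number from compound 3 to compound 4 (0.09 log units; within the scatter)). In this assay compound 4 is estimated at 4.5 mL.min-1.g-1 within an expected range (2.2 mL.min-1.g-1 to 9.5 mL.min-1.g-1).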

Compound 4, intrinsic clearance in microsomes: 6.4 mL.min-1.g-1
For compound 4 the middle estimate is 1.4-fold (0.15 log units) below the measured one; the measured number falls inside the stated range.
By their numbers in this assay, from the lowest: compounds 1, 3 and 4 (each within the scatter of the next, the first and the last beyond it). At a limit, below all of these: compound 2.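

In this assay, methylsulfanyl para to a large group does not separate from hydrogen (a 1.7-fold higher number from compound 3 to compound 4 (0.24 log units; within the scatter)), yet it does separate from cyano in the same place (a 2.6-fold higher number from compound 1 to compound 4 (0.41 log units; beyond the scatter)), although compound 1 and compound 3 stand level. Against the piperidin-4-yl of compound 2, the 4-(methylsulfanyl)phenyl gives the largest step in the series (an at least 12-fold higher number from compound 2 to compound 4 (1.10 log units; beyond the scatter)). Compound 2 gives a limit of the assay, not a number: the limit of < 0.5 mL.min-1.g-1 in this assay, at which 1 of the 4 values shown sits.

Still open, as far as these compounds go, is whether a dimethylamino group or a carboxylic acid on this phenyl, para to a large group, would bring the number closer to that limit.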